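The compounds below may be only part of what the source reports. "The series", "measured", "known", "first", "only" and "open" are said of these compounds alone.

Compound 1 `COC(=O)[C@@]1(C)CCC=C2[C@@H]1CC[C@@H](C)[C@]2(C)Cc1c[nH]c2ccc(Br)cc12` and compound 2 `COC(=O)[C@@]1(C)CCC=C2[C@@H]1CC[C@@H](C)[C@]2(C)Cc1c[nH]c2ccc(Cl)cc12` share one core and differ only in chloro in place of bromo on an aromatic carbon. In a functional assay on HBL-100 cells (Homo sapiens) for inhibition, read by sulforhodamine B assay, with a stated time of 48 h (on this read-out lower numbers stand for stronger inhibition of growth and higher numbers for weaker inhibition of growth), compound 1 gives 16000 nM, and compound 2 gives 17000 nM, a step of a 1.1-fold higher number from compound 1 to compound 2 (0.03 log units; within the scatter). Compound 3 `COC(=O)[C@@]1(C)CCC=C2[C@@H]1CC[C@@H](C)[C@]2(C)Cc1c[nH]c2c(Br)cccc12` has the same atoms as compound 1 joined differently; the difference between the two cores is not broken down here. In this assay compound 3 gives 18000 nM. Compound 4 `COC(=O)[C@@]1(C)CCC=C2[C@@H]1CC[C@@H](C)[C@]2(C)Cc1c[nH]c2c(Cl)cccc12` has not yet been measured in this assay; it differs from compound 3 by chloro in place of bromo on an aromatic carbon. This is the same kind of change as that between compound 1 and compound 2, though the surroundings differ: there the place was meta to a fused ring and para to a fused ring, here it is ortho to a fused ring and meta to a fused ring. Because the earlier step of a 1.1-fold higher number from compound 1 to compound 2 (0.03 log units; within the scatter) lay within the scatter, the expected step in this assay is a 1.1-fold higher number from compound 3 to compound 4 (0.02 log units; within the scatter). Compound 4 is therefore estimated at 19000 nM, with a likely range from 9500 nM to 38000 nM.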

Compound 4, concentration for 50% growth inhibition: 19000 nM
For compound 4 middle estimate and measured number coincide at the digits printed; low and high end bracket the measured number.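

Exchanging bromo for chloro on the core of compound 3 gives a 1.1-fold higher number from compound 3 to compound 4 (0.02 log units; within the scatter). In this assay, this step does not differ from the earlier one on the other core: the same change on two cores in this assay, a 1.1-fold higher number (0.03 log units; within the scatter) from compound 1 to compound 2 and a 1.1-fold higher number (0.02 log units; within the scatter) from compound 3 to compound 4, 1.0-fold (0.00 log units) apart, within the scatter of two such steps. Within the data shown here, the change therefore carried over between these two cores without moving the number beyond the scatter, but with only two pairs, both within the scatter, this does not show that it would behave the same way on any other core or in any other assay.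

The compounds shown leave open whether a different group at these places, such as fluoro, methoxy or an amine, would shift the number. They also leave open what a carboxylic acid in place of the ester would do.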